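The compounds below may be only part of what the source reports. "The series", "measured", "known", "first", "only" and "open" are said of these compounds alone.

Measured so far:
compound 1, `CCCC(C1CC1)n1c(=O)c(C)nc2c(-c3ccc(Cl)cc3Cl)ccnc21`: 4.3 nM
compound 2, `CC[C@H](COC)n1c(=O)c(C)nc2c(-c3ccc(Cl)cc3Cl)nccc21`: 150 nM
compound 3, `CCC(C1CC1)n1c(=O)c(C)nc2c(-c3cc(C#N)c(C)cc3Cl)ccnc21`: 4.8 nM

In a functional assay for antagonist activity at corticotropin-releasing factor receptor 1 (Rattus norvegicus) (on this read-out higher numbers stand for weaker inhibition and lower numbers for stronger inhibition), compound 1 gives 4.3 nM, the lowest of the three numbers. Compound 3 sits within the scatter of it, so no order between compound 1 and compound 3 can be read. Compound 2 gives 150 nM, and its gap to compound 1 lies well outside the scatter, on the weaker side; compound 2 carries the 1-(methoxymethyl)propyl group on a core arranged differently from that of compound 1, so the two values alone cannot be split between substituent and core.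

Compound 4, `CC[C@H](COC)n1c(=O)c(C)nc2c(-c3ccc(Cl)cc3Cl)ccnc21`, is not yet measured. It differs from compound 1 by 1-(methoxymethyl)propyl in place of 1-cyclopropylbutyl on an aromatic nitrogen. For the measured compounds named here, the cyclopropyl-bearing chain of compound 1 and compound 3 goes with the two low numbers; the only compound with the entering group, compound 2, gives a much higher number but on another core. A step weakening inhibition, modest but probably beyond the scatter, is expected in this assay. Compound 4 is estimated at 12 nM, with a range from 3 nM to 50 nM, which means an expected step of a 2.8-fold higher number from compound 1 to compound 4 (0.45 log units; beyond the scatter) in this assay.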

Compound 4, half-maximal inhibitory concentration: 4 nM
Estimate against measurement, compound 4: 3.0-fold (0.48 log units) above; measured number inside the range.
By their numbers in this assay, from the lowest: compounds 4, 1 and 3 (each within the scatter of the next); then compound 2.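

On the shared core of compound 1, in this assay, 1-(methoxymethyl)propyl can replace 1-cyclopropylbutyl on the aromatic nitrogen with a 1.1-fold lower number from compound 1 to compound 4 (0.03 log units; within the scatter) as the step, so the three-membered carbon ring and the larger chain are not required at this position for a number at this level. For the compounds shown here, this also separates the group from the core question left by the earlier compounds: compound 4 gives 4 nM and compound 2 gives 150 nM in this assay with the same 1-(methoxymethyl)propyl group and the same dichlorophenyl substituent, so the high number of compound 2 cannot be put on this group and goes with the different arrangement of its core. Nothing at hand explains why the two groups give numbers within the scatter of each other.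

Still open, going by these compounds, is whether this position tolerates a wider range of groups, such as a free hydroxymethyl chain, an amine-bearing chain or the opposite configuration at the defined stereocentre of 1-(methoxymethyl)propyl. Also open is whether 1-(methoxymethyl)propyl would behave the same way alongside the nitrile-bearing aryl group of compound 3, since that pairing stands outside the compounds shown here.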